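The source may report more compounds than this note shows. Statements on the series, on what has been measured and on what is new or still open speak of the compounds shown alone.

In a functional assay on MCF7 cells (Homo sapiens) for antiproliferative activity, read by MTT assay, with a stated time of 48 h (a lower number here means a stronger inhibitor, a higher number a weaker inhibitor), three compounds on one shared core have been measured. Compound 1 (`COc1ccc(-c2nn(-c3ccccc3)cc2CNc2ccc(Br)cc2)cc1`) gives 7020 nM and compound 2 (`Cc1ccc(-c2nn(-c3ccccc3)cc2CNc2ccc(Br)cc2)cc1`) gives 6890 nM while compound 3 (`Clc1ccc(-c2nn(-c3ccccc3)cc2CNc2ccc(Br)cc2)cc1`) gives 2620 nM as the lowest of the three numbers. Methyl in place of methoxy gives a 1.0-fold lower number from compound 1 to compound 2 (0.01 log units; within the scatter) and thus no real separation. Chloro in place of methoxy gives a 2.7-fold lower number from compound 1 to compound 3 (0.43 log units; beyond the scatter) and chloro in place of methyl gives a 2.6-fold lower number from compound 2 to compound 3 (0.42 log units; beyond the scatter) so both steps to chloro are modest.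

Compound 4 (`Brc1ccc(NCc2cn(-c3ccccc3)nc2-c2ccc(Br)cc2)cc1`) has not yet been measured. It differs from compound 3 by bromo in place of chloro on an aromatic carbon in a single place: bromo in place of chloro on an aromatic carbon, para to a large group, so that 4-chlorophenyl becomes 4-bromophenyl. Going by the values given here, no measured pair exchanges chloro for bromo, so the two modest steps bear on this change only indirectly. No step beyond the scatter is expected in this assay in either direction, and the expectation stays close to compound 3 with its 2620 nM as the anchor. The expected step is a 1.0-fold lower number from compound 3 to compound 4 (0.02 log units; within the scatter) by this estimate. Compound 4 is expected at 2500 nM within a range of 1200 nM to 5200 nM as estimated here.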

Compound 4, half-maximal inhibitory concentration: 5000 nM
For compound 4 the middle estimate is 2.0-fold (0.30 log units) below the measured one; the range from low to high includes it.
By their numbers in this assay, from the lowest: compounds 3, 4, 2 and 1 (each within the scatter of the next, the first and the last beyond it).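

In this assay the exchange of 4-chlorophenyl for 4-bromophenyl gives a 1.9-fold higher number from compound 3 to compound 4 (0.28 log units; within the scatter), so the two halogens on this aromatic carbon cannot be told apart. Bromo is equally unresolved from the two groups that chloro was separated from, with a 1.4-fold lower number from compound 2 to compound 4 (0.14 log units; within the scatter) and a 1.4-fold lower number from compound 1 to compound 4 (0.15 log units; within the scatter), so the separation seen for chloro is not reproduced by bromo as a step beyond the scatter. Nothing measured here accounts for this result.

As far as these compounds go, what remains open is whether a fluoro group, a trifluoromethyl group or a nitrile at this place would stand apart from chloro or fall within the same narrow spread. The same question holds for an amine or a carboxylic acid on this carbon.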